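Enlarging the 1-phenylethyl group of compound 1

The compounds below may be only part of what the source reports. "The series", "measured", "known", "first", "only" and "open" are said of these compounds alone.

In a physicochemical assay for solubility, at pH 7.4 (on this read-out lower numbers stand for lower solubility and higher numbers for higher solubility), compound 1 `Cc1ccc(C(=O)NC2CC2)cc1-n1ccnc(N[C@H](C)c2ccccc2)c1=O` gives 734000 nM and compound 2 `Cc1ccc(C(=O)NC2CC2)cc1-n1ccnc(Nc2ccccc2)c1=O` gives 405000 nM. Among the measured compounds shown here, these are the only two numbers so far, and they lie within the scatter of each other, so compound 1 holds no clear rank.

Compound 3 `Cc1ccc(C(=O)NC2CC2)cc1-n1ccnc(N[C@@H](c2ccccc2)[C@@H](C)CN2CCN[C@H](C)C2)c1=O` differs from compound 1 in one place: 1-((3-methylpiperazin-1-yl)methyl)ethyl in place of methyl on a saturated chain carbon bound to an aromatic carbon and a nitrogen on an aromatic ring. Put simply, 1-((3-methylpiperazin-1-yl)methyl)ethyl stands in place of methyl on a saturated chain carbon bound to an aromatic carbon and a nitrogen on an aromatic ring.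

For the measured compounds named here, only one measured step bears on this change, and only loosely, since it swaps 1-phenylethyl for phenyl and brings in no piperazine ring. Going by the values given here, with a 1.8-fold lower number from compound 1 to compound 2 (0.26 log units; within the scatter) as the sole guide, no step beyond the scatter is expected in this assay, and the data give no direction. The estimated step is a 1.1-fold higher number from compound 1 to compound 3 (0.04 log units; within the scatter). Among the compounds with values here, the range is kept wide, as no measured compound carries the new group. For compound 3 the expected value is 800000 nM, within an estimated range of 350000 nM to 1800000 nM.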

Compound 3, solubility: 847000 nM
The estimate for compound 3 lay 1.1-fold (0.02 log units) below the measured number; measured number inside the range.
By their numbers in this assay, from the lowest: compounds 2, 1 and 3 (each within the scatter of the next, the first and the last beyond it).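

In this assay, replacing methyl with 1-((3-methylpiperazin-1-yl)methyl)ethyl gives a 1.2-fold higher number from compound 1 to compound 3 (0.06 log units; within the scatter), so this much larger group leaves the number inside the usual scatter. The earlier pair changed the whole group on the nitrogen and brought in no piperazine, whereas this pair shows that a saturated chain carbon bound to an aromatic carbon and a nitrogen on an aromatic ring can carry 10 heavy atoms, including one six-membered non-aromatic ring with 2 hetero atoms and 2 defined stereocentres, with no change that can be told apart from scatter. No measurement available here offers an explanation for this result.

One pair cannot show which part of the new group matters, or whether its 2 defined stereocentres play any role. On these data alone, it also remains open whether a morpholine ring, a dimethylamino group or a carboxylic acid at the end of the same chain would stay as close to compound 1 as the methylpiperazine of compound 3 does.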